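Growing the ketone chain in a furyl dihydropyrimidinone series

A few compounds are considered here, and "the series" means these few. Any claim that something is new, unique, unknown or untested is made for them only; others in the source may bear on it.

Of the compounds shown here, three sharing one core have been measured in an assay on membranes from CHO cells for displacement of a labelled ligand from adenosine receptor A1 (Homo sapiens), read by scintillation counting, with a stated time of 60 min, tested at 1 uM; on this read-out lower numbers stand for less inhibition and higher numbers for more inhibition at the one concentration tested (going by the name of the read-out). Compound 1 `COC(=O)C1=C(C)NC(=O)NC1c1ccoc1` gives 8%, compound 2 `CCCOC(=O)C1=C(C)NC(=O)NC1c1ccoc1` gives 50%, and compound 3 `CC(=O)C1=C(C)NC(=O)NC1c1ccoc1` gives 6%. Compound 3 and compound 1 sit within the scatter of each other (a number 2 percentage points lower from compound 1 to compound 3 (within the scatter)), while a number 44 percentage points lower from compound 2 to compound 3 (beyond the scatter) shows compound 3 far beneath compound 2.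

Compound 4 `CC1=C(C(=O)CC(C)C)C(c2ccoc2)NC(=O)N1` is not yet measured. It differs from compound 3 by isopropyl in place of hydrogen on a saturated chain carbon bound to a carbonyl carbon. The two informative steps are a number 42 percentage points higher from compound 1 to compound 2 (beyond the scatter) and a number 44 percentage points lower from compound 2 to compound 3 (beyond the scatter): in both, a larger saturated chain on the carbonyl-bearing substituent went with much more inhibition. The change to compound 4 likewise enlarges that chain, though on a carbon bound to the carbonyl carbon rather than through an oxygen, so the precedent is only partly matching.

On that basis an increase beyond the scatter is expected for compound 4 in this assay, roughly a number 24 percentage points higher from compound 3 to compound 4 (beyond the scatter). The estimate for compound 4 is 30%, with a range from 5% to 60%.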

Compound 4, a percentage reported as inhibition, at one concentration (the size of the read-out at that concentration, not a potency): 23%
The estimate for compound 4 lay 7 percentage points above the measured number; the range from low to high includes it.
By their numbers in this assay, from the lowest: compounds 3 and 1 (each within the scatter of the next); then compound 4; then compound 2.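

In this assay the ketone series now shows a gain of its own, with a number 17 percentage points higher from compound 3 to compound 4 (beyond the scatter) for isopropyl in place of hydrogen on a saturated chain carbon bound to a carbonyl carbon; until now a rise had been seen only among the esters. Isobutyl on the carbonyl carbon also outdoes methoxy, with a number 15 percentage points higher from compound 1 to compound 4 (beyond the scatter), but it does not match propoxy, with a number 27 percentage points lower from compound 2 to compound 4 (beyond the scatter), so at this position the propoxy ester remains ahead of the isobutyl ketone. Nothing available accounts for these differences.

The compounds shown leave open whether a straight butyl chain or a cyclopentyl ring on the carbonyl carbon would reach the level of compound 2. They also do not show whether a longer ester such as butoxy would go higher still, or how an amide at this carbonyl would behave.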